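The compounds below may be only part of what the source reports. "The series", "measured", "known", "first", "only" and "open" are said of these compounds alone.

In a functional assay on SMMC-7721 cells (Homo sapiens) for cytotoxicity, read by MTT assay, with a stated time of 72 h (on this read-out lower numbers stand for stronger inhibition and higher numbers for weaker inhibition), compound 1 `O=C(CCl)Nc1ccc(C(=O)/C=C/c2ccc(Cl)cc2)cc1` gives 8160 nM. Compound 2 `O=C(CSC(=S)N[C@H]1CCOC1=O)Nc1ccc(C(=O)/C=C/c2ccc(Cl)cc2)cc1` gives > 128000 nM, which is a limit of the assay and not a number. Going by the values given here, the large step of an at least 15-fold higher number from compound 1 to compound 2 (1.19 log units; beyond the scatter) lies beyond the scatter, but it replaces a chlorine on a saturated chain carbon bound to a carbonyl carbon, a different place from the one that changes next.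

Compound 3 `O=C(CSC(=S)N[C@H]1CCOC1=O)Nc1ccc(C(=O)/C=C/c2cccc(Cl)c2)cc1` has the same atoms as compound 2, joined differently: 3-chlorophenyl in place of 4-chlorophenyl on a double-bonded chain carbon bound to a double-bonded chain carbon. The chlorophenyl group stays on a double-bonded chain carbon bound to a double-bonded chain carbon, and only its chlorine takes a new place. Among the compounds with values here, no measured step moves that chlorine, so none bears directly on this change. Within the data shown here, the only close guide is compound 2 with its > 128000 nM, and this guide is itself a limit. No step beyond the scatter is therefore expected in this assay, and the result may again be only a limit. For compound 3 the expected value is 100000 nM, with an estimated range of 30000 nM to 200000 nM. The expected step is an at least 1.2-fold lower number from compound 2 to compound 3 (0.10 log units; that floor lies within the scatter).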

Compound 3, half-maximal inhibitory concentration: 39100 nM
For compound 3 the middle estimate is 2.6-fold (0.41 log units) above the measured one; measured number inside the range.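

In this assay, putting 3-chlorophenyl in place of 4-chlorophenyl on a double-bonded chain carbon bound to a double-bonded chain carbon gives an at least 3.2-fold lower number from compound 2 to compound 3 (0.51 log units; beyond the scatter), so this part of the molecule responds to where its chlorine sits, even though the two groups hold the same atoms. Compound 3 gives 39100 nM, a true number, which shows that the large sulfur-containing group that replaces the chain chlorine of compound 1 does not on its own push a compound past what the assay can read. The real size of the step remains unknown, and it can only be stated as a floor, because compound 2 gives a limit and not a number: the limit of > 128000 nM in this assay, at which 1 of the 3 values shown sits.

The compounds shown leave open whether the same move of the chlorine would matter in a compound that keeps the chain chlorine of compound 1. They also leave open whether chlorine itself is needed on this ring, which a fluorine or a methoxy group in its place, or a plain phenyl group without any such addition, would help to settle.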